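Enlarging the Saturated Ring Attached to the Core of Compound 1

The compounds below may be only part of what the source reports. "The series", "measured", "known", "first", "only" and "open" are said of these compounds alone.

Three measured compounds share one core and differ only in the group carried by a single aromatic carbon. Compound 1 is `COc1ccc(Br)cc1CCc1c(Cl)cccc1-c1nccn1C`; in a functional assay on HEK293 cells (Homo sapiens), read by cAMP accumulation (a lower number here means a stronger inhibitor, a higher number a weaker inhibitor), compound 1 gives 1100 nM. Compound 2, `COc1ccc(Br)cc1CCc1c(Cl)cccc1-c1nccn1C(C)C`, gives 1400 nM in this assay, and compound 3, `COc1ccc(Br)cc1CCc1c(Cl)cccc1-c1ncc2n1CCC2`, gives 710 nM. Compound 1 thus lies within the scatter of both other compounds: a 1.3-fold higher number from compound 1 to compound 2 (0.10 log units; within the scatter) and a 1.5-fold lower number from compound 1 to compound 3 (0.19 log units; within the scatter).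

Compound 4, `COc1ccc(Br)cc1CCc1c(Cl)cccc1-c1ncc2n1CCCC2`, has not yet been measured. It differs from compound 1 in that (a group of 9 heavy atoms (7 carbon, 2 nitrogen; one five-membered aromatic ring with 2 hetero atoms, one six-membered non-aromatic ring with 1 hetero atom) in place of a group of 6 heavy atoms (4 carbon, 2 nitrogen; one five-membered aromatic ring with 2 hetero atoms), on an aromatic carbon). The closest guide is the step to compound 3, where a five-membered non-aromatic ring was joined at the same aromatic carbon and gave a 1.5-fold lower number from compound 1 to compound 3 (0.19 log units; within the scatter); a 2.0-fold lower number from compound 2 to compound 3 (0.29 log units; within the scatter) points the same way but also stays within the scatter. No change at this aromatic carbon has so far moved the number beyond the scatter, so none beyond it is expected for compound 4 either, at most a slight drift toward a lower number in line with compound 3. The expected step is therefore a 1.4-fold lower number from compound 1 to compound 4 (0.14 log units; within the scatter). Compound 4 is expected to give about 800 nM in this assay, with a likely range from 350 nM to 1800 nM.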

Compound 4, half-maximal inhibitory concentration: 590 nM
Compound 4: middle estimate off by 1.4-fold (0.13 log units), on the high side, and the stated range covers the measured number.
By their numbers in this assay, from the lowest: compounds 4, 3, 1 and 2 (each within the scatter of the next, the first and the last beyond it).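

In this assay this aromatic carbon now gives its first step beyond the scatter, which is a 2.4-fold lower number from compound 2 to compound 4 (0.38 log units; beyond the scatter) and counts as modest. Set against the 1-methyl-1H-imidazol-2-yl group of compound 1, the same new group stays inside the scatter, with a 1.9-fold lower number from compound 1 to compound 4 (0.27 log units; within the scatter) as the step, so only the two ends of this small series can be told apart. Going from the five-membered to the six-membered non-aromatic ring shows no readable effect, with a 1.2-fold lower number from compound 3 to compound 4 (0.08 log units; within the scatter) as the step, so compound 3 and compound 4 cannot be separated in this assay, and nothing here shows that ring size matters.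

Whether an amine or a carboxylic acid on the saturated ring, or a longer chain such as butyl on the aromatic nitrogen, would move the number further in either direction remains an open question. No measurement at hand accounts for the order of these numbers.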